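A few compounds are considered here, and "the series" means these few. Any claim that something is new, unique, unknown or untested is made for them only; others in the source may bear on it.

Measured compounds in the series:
- compound 1, `O=C(/C=C/c1cccc(Cl)c1Cl)Nc1cc2c(Nc3ccc(F)c(Cl)c3)ncnc2cc1O[C@H]1CCOC1`: 30500 nM
- compound 2, `COc1cc(/C=C/C(=O)Nc2cc3c(Nc4ccc(F)c(Cl)c4)ncnc3cc2OC)cc(OC)c1`: "not determined" (no result reported)
- compound 3, `COc1cc2ncnc(Nc3ccc(F)c(Cl)c3)c2cc1NC(=O)/C=C/c1ccc(C#N)cc1`: "not determined" (no result reported)

For the measured compounds named here, in a functional assay on HeLa cells (Homo sapiens) for cytotoxicity, read by MTT assay, with a stated time of 72 h (a higher number here means a weaker inhibitor, a lower number a stronger inhibitor), compound 1 gives 30500 nM and stands alone as the only number in the set: compound 2 gives "not determined" (no result reported) and compound 3 gives "not determined" (no result reported) in this assay, so nothing can be said of how the three compare, and no step between two measured compounds is available for reference.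

The unmeasured compound 4, `O=C(/C=C/c1cc(Br)c(O)c(Br)c1)Nc1cc2c(Nc3ccc(F)c(Cl)c3)ncnc2cc1O[C@H]1CCOC1`, keeps the shared core of compound 1 and changes one place:

3,5-dibromo-4-hydroxyphenyl in place of 2,3-dichlorophenyl on a double-bonded chain carbon bound to a double-bonded chain carbon

Going by the values given here, with no measured step in this assay to lean on, the expectation for compound 4 rests on compound 1 alone; the step from compound 1 to compound 4 is expected to stay within the usual scatter, with a slight lean toward a lower number, giving a 1.3-fold lower number from compound 1 to compound 4 (0.10 log units; within the scatter) as the estimate. Compound 4 is therefore expected to give 24000 nM in this assay, with a range from 8000 nM to 75000 nM.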

Compound 4, half-maximal inhibitory concentration: 27700 nM
Estimate against measurement, compound 4: 1.2-fold (0.06 log units) below; the measured number falls inside the stated range.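

In this assay, for the compounds shown here, the first readable step puts 3,5-dibromo-4-hydroxyphenyl in place of 2,3-dichlorophenyl on a double-bonded chain carbon bound to a double-bonded chain carbon, and it reads as a 1.1-fold lower number from compound 1 to compound 4 (0.04 log units; within the scatter). This position therefore carries either aryl group with no difference beyond the scatter, even though the entering group brings a hydroxyl, with its hydrogen-bond donor and acceptor, and two bromines where the leaving group has two chlorines. Nothing shown separates the contributions of the hydroxyl and the halogens, and no measurement bears on why the two compounds read alike.

Steps involving compound 2 or compound 3 cannot be read, so the series still has only one step at this position. Open, from the compounds shown here alone, is whether an amine or a carboxylic acid on the phenyl ring, or a longer chain in place of the ethenyl link, would move the number beyond the scatter from the level of compound 1.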